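Cyclobutyl to cyclopentyl ester on a thiophene analogue

The source may hold more compounds than are shown below. What is called first, only, known or untested is meant among the compounds shown, and "the series" means these compounds.

Three compounds were measured in an assay on membranes from CHO cells for displacement of a labelled ligand from adenosine receptor A1 (Homo sapiens), read by scintillation counting, with a stated time of 60 min, tested at 1 uM; on this read-out lower numbers stand for less inhibition and higher numbers for more inhibition at the one concentration tested (going by the name of the read-out). Compound 1, `CC1=C(C(=O)OC2CCC2)C(c2ccoc2)NC(=O)N1`, gives 20% in this assay. Compound 2, `CC1=C(C(=O)OC2CCCC2)C(c2ccoc2)NC(=O)N1`, differs from compound 1 by cyclopentyl in place of cyclobutyl on an oxygen next to a carbonyl group. In this assay compound 2 gives 6%, so that a number 14 percentage points lower from compound 1 to compound 2 (beyond the scatter). Compound 3, `CC1=C(C(=O)OC2CCC2)C(c2ccsc2)NC(=O)N1`, differs from compound 1 by thiophen-3-yl in place of furan-3-yl on a saturated ring carbon. In this assay compound 3 gives 40%, with a number 20 percentage points higher from compound 1 to compound 3 (beyond the scatter). Compound 3 thus stands highest of the three in this assay, and its lead over both compound 1 and compound 2 is beyond the scatter.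

Compound 4, `CC1=C(C(=O)OC2CCCC2)C(c2ccsc2)NC(=O)N1`, has not yet been measured in this assay. It differs from compound 3 by cyclopentyl in place of cyclobutyl on an oxygen next to a carbonyl group, and this is the same change that turns compound 1 into compound 2, made at the same place; the two cores differ as described by thiophen-3-yl in place of furan-3-yl on a saturated ring carbon. Within the data shown here, only one measured example of this change exists, so how it carries over onto the core of compound 3 is not known from these data.

If the change behaves on compound 3 as it did on compound 1, a step of similar size is expected, and the estimate for compound 4 is therefore a number 14 percentage points lower from compound 3 to compound 4 (beyond the scatter), resting on a number 14 percentage points lower from compound 1 to compound 2 (beyond the scatter) and on the value of compound 3 of 40%. Compound 4 is accordingly expected to give about 26% in this assay, with a plausible range from 10% to 42%.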

Compound 4, a percentage reported as inhibition, at one concentration (the size of the read-out at that concentration, not a potency): 5%
Estimate against measurement, compound 4: 21 percentage points above, outside the stated range (below it).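

On the core of compound 3, cyclopentyl in place of cyclobutyl on an oxygen next to a carbonyl group again lowered the number in this assay, with a number 35 percentage points lower from compound 3 to compound 4 (beyond the scatter), so the direction of the step carried over from one core to the other but its size did not: the same change on two cores in this assay, a number 14 percentage points lower (beyond the scatter) from compound 1 to compound 2 and a number 35 percentage points lower (beyond the scatter) from compound 3 to compound 4, 21 percentage points apart, beyond the scatter of two such steps. Seen from the other side, the step from furan-3-yl to thiophen-3-yl did not carry over either, since with cyclopentyl in place of cyclobutyl there is a number 1 percentage points lower from compound 2 to compound 4 (within the scatter), and the gain seen with cyclobutyl is absent: the same change on two cores in this assay, a number 20 percentage points higher (beyond the scatter) from compound 1 to compound 3 and a number 1 percentage points lower (within the scatter) from compound 2 to compound 4, 21 percentage points apart, beyond the scatter of two such steps. These results show that, among these four compounds, the two changes do not simply add up, but they rest on one pair per core, so they do not show how either change would behave on a further core, and they give no reason for the difference.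

The compounds shown leave open whether a cyclopropyl group or an open chain such as isopropyl on the same oxygen would keep the number nearer that of compound 3. They also leave open how a phenyl group in place of thiophen-3-yl would respond to the same change from cyclobutyl to cyclopentyl.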